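The source may report more compounds than this note shows. Statements on the series, on what has been measured and on what is new or still open speak of the compounds shown alone.

Working notes on the series. Of the compounds shown here, three are measured so far: compound 1 `COc1ccc(-n2nc(C(=O)Nc3ccccc3C)nc2-c2cc(OC)c(OC)c(OC)c2)cc1`, compound 2 `COc1ccc(-n2nc(C(=O)Nc3ccc(C(F)(F)F)cc3)nc2-c2cc(OC)c(OC)c(OC)c2)cc1` and compound 3 `COc1ccc(-n2nc(C(=O)Nc3ccc(C(=O)O)cc3)nc2-c2cc(OC)c(OC)c(OC)c2)cc1`, which share one core and differ only in the aryl group carried on the amide-type nitrogen. In a functional assay on the whole organism for inhibition, with Rattus norvegicus as the target, read by paw edema, with stated times of 30 min and 4 h, at a dose of 0.28 mmol/kg by the oral route (a lower number here means less inhibition, a higher number more inhibition at the dose given (going by the name of the read-out)), compound 1 gives 46%, the lowest of the three numbers. Compound 2 gives 56%, and compound 3 gives 69%. The measured steps are a number 10 percentage points higher from compound 1 to compound 2 (within the scatter), a number 23 percentage points higher from compound 1 to compound 3 (beyond the scatter) and a number 13 percentage points higher from compound 2 to compound 3 (beyond the scatter); the nearest neighbour of compound 1 is compound 2, within the scatter, the furthest is compound 3, beyond it.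

Compound 4 `COc1ccc(-n2nc(C(=O)Nc3ccccc3)nc2-c2cc(OC)c(OC)c(OC)c2)cc1` is not yet measured. It differs from compound 1 by hydrogen in place of methyl on an aromatic carbon. Within the data shown here, none of the measured steps bears directly on this change: both steps away from compound 1 exchange the whole aryl group, and the smaller of them stays within the scatter. The step of a number 4 percentage points higher from compound 1 to compound 4 (within the scatter) is therefore expected to be small, in either direction, not beyond the scatter. For compound 4 in this assay the estimate is 50%, expected to fall between 30% and 70%.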

Compound 4, a percentage reported as inhibition, in the whole organism at one dose (the size of the read-out at that dose, not a potency): 50%
Compound 4: the middle estimate sits on the measured number at the digits printed; measured number inside the range.
By their numbers in this assay, from the lowest: compounds 1, 4 and 2 (each within the scatter of the next); then compound 3.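

In this assay, the methyl of the 2-methylphenyl group, ortho to a large group, can give way to hydrogen with no step beyond the scatter: a number 4 percentage points higher from compound 1 to compound 4 (within the scatter). Phenyl now serves as an unsubstituted reference for the single-place changes on this ring: a number 6 percentage points lower from compound 2 to compound 4 (within the scatter) leaves trifluoromethyl within the scatter of hydrogen, whereas a number 19 percentage points lower from compound 3 to compound 4 (beyond the scatter) sets carboxy apart, so among these groups only carboxy gives a step beyond the scatter from hydrogen. Nothing at hand gives a reason for this difference.

Going by these compounds, whether an amine or a methyl ester in place of the carboxy would give a number like that of compound 3 stays open, as does the outcome for a longer chain in place of the methyl of compound 1. With one dose, these percentages do not give potency.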